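The compounds below may be only part of what the source reports. "The series", "measured", "known", "first", "only" and "open" are said of these compounds alone.

In a functional assay on NCI-H460 cells (Homo sapiens) for cytotoxicity, read by MTT assay, with a stated time of 68 h (a higher number here means a weaker inhibitor, a lower number a stronger inhibitor), three compounds with a shared core have been measured. Compound 1 `COc1ccc(-c2cccc(NC(=O)C(Cl)Cl)c2)cc1` gives 43300 nM, and compound 2 `Cc1ccc(-c2cccc(NC(=O)C(Cl)Cl)c2)cc1` gives 8000 nM. Compound 3 `O=C(Nc1cccc(-c2ccc(F)cc2)c1)C(Cl)Cl` gives > 50000 nM, which is a limit of the assay and not a number.

Compound 4 `O=C(Nc1cccc(-c2ccc(C(F)(F)F)cc2)c1)C(Cl)Cl` carries trifluoromethyl in place of the fluoro of compound 3, on an aromatic carbon para to a large group: trifluoromethyl in place of fluoro on an aromatic carbon. Three measured steps at that carbon bear on this change. Methyl in place of methoxy gives a 5.4-fold lower number from compound 1 to compound 2 (0.73 log units; beyond the scatter). Fluoro in place of methyl gives an at least 6.2-fold higher number from compound 2 to compound 3 (0.79 log units; beyond the scatter). Fluoro in place of methoxy gives an at least 1.1-fold higher number from compound 1 to compound 3 (0.06 log units; that floor lies within the scatter).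

A swap at this carbon can therefore shift the number by a modest amount, although compound 3 offers only a limit as a starting point. A modest move towards a lower number is expected, with compound 2 at 8000 nM as the nearest guide. The expected change is an at least 2.7-fold lower number from compound 3 to compound 4 (0.44 log units; beyond the scatter). For compound 4 the estimated value is 18000 nM, within an expected range of 6000 nM to 50000 nM.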

Compound 4, half-maximal inhibitory concentration: 33600 nM
For compound 4 the middle estimate is 1.9-fold (0.27 log units) below the measured one; low and high end bracket the measured number.
By their numbers in this assay, from the lowest: compound 2; then compounds 4 and 1 (each within the scatter of the next). At a limit, above all of these: compound 3.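

In this assay, trifluoromethyl and methoxy at this carbon cannot be told apart, with a 1.3-fold lower number from compound 1 to compound 4 (0.11 log units; within the scatter). Methyl now also stands clear of a second group that gives a real number rather than a limit, with a 4.2-fold higher number from compound 2 to compound 4 (0.62 log units; beyond the scatter), so compound 2 keeps the lowest number of the four. Against compound 3 only a floor can be read, an at least 1.4-fold lower number from compound 3 to compound 4 (0.17 log units; that floor lies within the scatter), and the value of compound 3 remains a limit of the assay: the limit of > 50000 nM in this assay, at which 1 of the 4 values shown sits.

The compounds shown leave open whether the lower number belongs to methyl alone or extends to a longer chain such as ethyl, or to an amine or a hydroxyl at this carbon. They also leave open how far compound 3 lies beyond its limit, and so how large its true step to compound 4 is.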